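Extending the Chain on a Series Without Measurable Inhibition

This account rests on a few compounds, and the source may have more. Where it says the series, first, only, none or still open, it means among the compounds named here.

Of the compounds shown here, three have so far been tested in a functional assay on A549 cells (Homo sapiens) for inhibition, read by MTT assay, with a stated time of 24 h; a lower number here means a stronger inhibitor, a higher number a weaker inhibitor. Compound 1 `[O-]/[N+](=C\c1cn(-c2ccccc2)nn1)c1ccccc1` gives only a limit of the assay in this assay, > 100000 nM. Compound 2 `CCCCCCCCCCn1cc(/C=[N+](\[O-])c2ccccc2)nn1` also gives only a limit, > 100000 nM. Compound 3 `CCCCCCCCn1cc(/C=[N+](\[O-])Cc2ccccc2)nn1` likewise gives only a limit, > 100000 nM. Where compound 3 stands on the numbers shown is therefore plain: it sits at the same limit as its two companions, and the limit of > 100000 nM in this assay, at which 3 of the 3 values shown sit, covers every value so far. Going by the values given here, no two of the three differ in a single place, so no measured step exists from which the size or direction of a change could be read.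

Compound 4 `CCCCCCCCCCn1cc(/C=[N+](\[O-])Cc2ccccc2)nn1` differs from compound 3 by ethyl in place of hydrogen on a saturated chain carbon, eight bonds along the chain from an aromatic nitrogen. The data give no ground for expecting this change to lift a compound off the limit; the step her estimate means, a step that the limit leaves unreadable from compound 3 to compound 4, is expected to be none beyond the scatter. Compound 4 is accordingly expected to give an estimated 150000 nM, within a range from 60000 nM to 400000 nM, and most probably again only a limit.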

Compound 4, half-maximal inhibitory concentration: > 100000 nM
Compound 4: a limit, no number; the forecaster's own chance of this, stated with the estimate: 85%; the middle value lies beyond the limit too.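

Compound 4 gives only a limit, > 100000 nM. The steps to it from compound 3 and from compound 2 cannot be read, because every value shown sits at the same limit: the limit of > 100000 nM in this assay, at which 4 of the 4 values shown sit. The compounds shown leave open whether any of these four differ at all in this assay, and whether any change brings measurable inhibition.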